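Aryl replacement on the ring nitrogen of the shared core

A few compounds are considered here, and "the series" means these few. Any claim that something is new, unique, unknown or untested is made for them only; others in the source may bear on it.

Compound 3 `CC(C)OC(=O)N1CCC(Oc2ncnc3c2CCN3c2ccc(F)cn2)CC1` gives only a limit, > 10000 nM, in a functional assay on CHO-K1 cells for agonist activity at Glucose-dependent insulinotropic receptor (Homo sapiens), read by a luciferase reporter, with a stated time of 5 h; a higher number here means that more compound is needed for the effect, a lower number that less compound is needed. Compound 1 `CC(C)OC(=O)N1CCC(Oc2ncnc3c2CCN3c2ccc(S(C)(=O)=O)cc2)CC1` gives 126 nM in this assay, and compound 2 `CC(C)OC(=O)N1CCC(Oc2ncnc3c2CCN3c2ccc(-c3nccs3)cc2F)CC1` gives 79.4 nM. Within the data shown here, the one single-point step measured so far, an at least 79-fold higher number from compound 1 to compound 3 (1.89 log units; beyond the scatter), is large, and its end sits at the limit of > 10000 nM in this assay, at which 1 of the 3 values shown sits. Compound 4 `CSc1ccc(N2CCc3c(OC4CCN(C(=O)OC(C)C)CC4)ncnc32)cc1F` carries a group of 9 heavy atoms (7 carbon, 1 fluorine, 1 sulfur; one six-membered aromatic ring of carbon only) in place of a group of 7 heavy atoms (5 carbon, 1 nitrogen, 1 fluorine; one six-membered aromatic ring with 1 hetero atom), on a nitrogen on an aromatic ring in a ring. This change undoes the kind of swap seen in an at least 79-fold higher number from compound 1 to compound 3 (1.89 log units; beyond the scatter), returning a carbon-only aromatic ring to the ring nitrogen, so a large step downward in this assay is expected, moving compound 4 back toward the region of compound 1 and compound 2. Compound 4 is therefore estimated at 150 nM, within 40 nM to 600 nM, which means an expected step of an at least 66-fold lower number from compound 3 to compound 4 (1.82 log units; beyond the scatter).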

Compound 4, half-maximal effective concentration: 398 nM
Estimate against measurement, compound 4: 2.7-fold (0.42 log units) below; low and high end bracket the measured number.
By their numbers in this assay, from the lowest: compounds 2 and 1 (each within the scatter of the next); then compound 4. At a limit, above all of these: compound 3.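

Replacing 5-fluoropyridin-2-yl on the ring nitrogen with the sulfur-bearing, carbon-only aromatic ring gives an at least 25-fold lower number from compound 3 to compound 4 (1.40 log units; beyond the scatter). A carbon-only aromatic ring at this position does not settle the number by itself: the change from 4-(methylsulfonyl)phenyl gives a 3.2-fold higher number from compound 1 to compound 4 (0.50 log units; beyond the scatter). Compound 3 remains a limit: the limit of > 10000 nM in this assay, at which 1 of the 4 values shown sits.

The compounds shown do not separate the effect of the ring nitrogen in 5-fluoropyridin-2-yl from that of the other substituents on the ring. From the compounds shown here alone, how an amine or a carboxylic acid on this aromatic ring would read in this assay also remains open.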